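A few compounds are considered here, and "the series" means these few. Any claim that something is new, unique, unknown or untested is made for them only; others in the source may bear on it.

Working notes on a short series sharing one core. In a functional assay on HT-29 cells (Homo sapiens) for antiproliferative activity, read by MTT assay, with a stated time of 48 h (on this read-out lower numbers stand for stronger inhibition and higher numbers for weaker inhibition), compound 1 (`COc1ccc(OC)c(/C=N/c2c(C#N)ncn2-c2ccc(F)cc2)c1`) gives 16300 nM while compound 2 (`N#Cc1ncn(-c2ccc(F)cc2)c1/N=C/c1ccc([N+](=O)[O-])cc1`) gives 15900 nM and compound 3 (`COc1ccc(/C=N/c2c(C#N)ncn2-c2ccc(F)cc2)cc1OC`) gives 7230 nM on the same read-out. Together with compound 1, compound 2 stands at the upper end of these three numbers. Its value lies within the scatter of that of compound 1, whereas compound 3 has a lower number, a gap beyond the scatter.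

The next entry is compound 4 (`CC(C)c1ccc(/C=N/c2c(C#N)ncn2-c2ccc(F)cc2)cc1`), which carries isopropyl in place of nitro on an aromatic carbon, para to a large group (isopropyl in place of nitro on an aromatic carbon). Among the compounds with values here, no two measured compounds differ in one place only, so the size of this change has not been observed directly. The three measured numbers stay fairly close together, with compound 3 at 7230 nM and compound 2 at 15900 nM despite their different groups. On that basis, no step beyond the scatter is expected in this assay and a somewhat lower number is the likelier direction. The estimate amounts to a 1.4-fold lower number from compound 2 to compound 4 (0.16 log units; within the scatter) and lies within the scatter. For compound 4 the estimated value is 11000 nM with an expected range from 5000 nM to 25000 nM in this read-out.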

Compound 4, half-maximal inhibitory concentration: > 25000 nM
Compound 4 was reported as a limit (the forecaster's own chance of this, stated with the estimate: 8%); middle value at least 2.2-fold (0.35 log units) away from the limit.
By their numbers in this assay, from the lowest: compound 3; then compounds 2 and 1 (each within the scatter of the next). At a limit, above all of these: compound 4.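

In this assay compound 4 gives > 25000 nM, which is a limit of the assay and not a number, so only one side of its activity can be read. The series now has its first change in one place, on the aromatic carbon para to a large group, and isopropyl in place of nitro there gives an at least 1.5-fold higher number from compound 2 to compound 4 (0.19 log units; that floor lies within the scatter), so the number does not go down on this change, and the size of the step is known only as a floor. The swap takes away the two hydrogen-bond acceptors counted for nitro and brings in none, but this single pair cannot tie that count to the result, and what can be said of the reading itself stops at the limit: the limit of > 25000 nM in this assay, at which 1 of the 4 values shown sits.

Going by these compounds, how far compound 4 really lies beyond the limit stays open, and so does whether the same swap would give a step of this kind on another substitution pattern of the ring. Also open, on these data alone, is how an amine, a carboxylic acid or a longer alkyl chain on this aromatic carbon would read against nitro and isopropyl.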